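The source may report more compounds than this note shows. Statements on the series, on what has been measured and on what is new or still open speak of the compounds shown alone.

Measured in a functional assay on HepG2 cells (Homo sapiens) for antiproliferative activity, read by sulforhodamine B assay, with a stated time of 48 h; on this read-out higher numbers stand for weaker inhibition and lower numbers for stronger inhibition:
- compound 1 `COc1cccc(/C=C/C(=O)/C=C(O)/C=C/c2cccc(OC)c2OC)c1OC`: 12900 nM
- compound 2 `COc1cccc(/C=C/C(=O)C(=Cc2ccc(F)cc2)C(=O)/C=C/c2cccc(OC)c2OC)c1OC`: 580 nM

Compound 2, at 580 nM, holds the lower of the two numbers, and its gap to compound 1 lies beyond the scatter. Compound 3 `COc1ccc(C=C(C(=O)/C=C/c2cccc(OC)c2OC)C(=O)/C=C/c2cccc(OC)c2OC)cc1OC` is still unmeasured. It has 3,4-dimethoxyphenyl in place of 4-fluorophenyl on a double-bonded chain carbon bound to a double-bonded chain carbon. For the measured compounds named here, no measured pair shows the effect of this change, so the expectation is loose. A small upward step is expected in this assay, a 1.4-fold higher number from compound 2 to compound 3 (0.14 log units; within the scatter). The estimated value for compound 3 is 800 nM, with an expected range of 250 nM to 2600 nM.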

Compound 3, half-maximal inhibitory concentration: 200 nM
The estimate for compound 3 lay 4.0-fold (0.60 log units) above the measured number; the whole stated range lies above it.
By their numbers in this assay, from the lowest: compound 3; then compound 2; then compound 1.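

In this assay, replacing 4-fluorophenyl with 3,4-dimethoxyphenyl on a double-bonded chain carbon bound to a double-bonded chain carbon gives a 2.9-fold lower number from compound 2 to compound 3 (0.46 log units; beyond the scatter). The number at this position therefore responds to the choice of aryl group, and the entering group, with more heavy atoms and with hydrogen-bond acceptors, is accepted without loss. No available data explain the step.

This single step cannot separate the loss of fluorine from the gain of the methoxy groups. It also leaves open how a single methoxy group or a dimethylamino group on the same phenyl ring would read.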